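Stretching the Chain on the Ring Nitrogen

A few compounds are considered here, and "the series" means these few. Any claim that something is new, unique, unknown or untested is made for them only; others in the source may bear on it.

Measured so far in a functional assay on trachea (Cavia porcellus); on this read-out lower numbers stand for stronger inhibition and higher numbers for weaker inhibition:
compound 1 `CO[C@@]12CCN(C)C[C@H]1[C@H](c1ccccc1)C(C#N)=C(N)O2` gives 19800 nM
compound 2 `CO[C@@]12CCN(Cc3ccccc3)C[C@H]1[C@H](c1ccccc1)C(C#N)=C(N)O2` gives 22600 nM
compound 3 `CO[C@@]12CCN(C)C[C@H]1[C@H](c1ccc(Br)cc1)C(C#N)=C(N)O2` gives 7900 nM

Compound 3 holds the lowest number of the three, which here means the strongest inhibition. Its nearest neighbour is compound 1, reached by a 2.5-fold lower number from compound 1 to compound 3 (0.40 log units; beyond the scatter), a modest step that comes from putting bromo in place of hydrogen on an aromatic carbon. Compound 2 lies a little further away. The step of a 1.1-fold higher number from compound 1 to compound 2 (0.06 log units; within the scatter), in which phenyl replaced hydrogen on a saturated chain carbon bound to the amine nitrogen in the ring, stayed within the scatter, so a large group at that position left the read-out essentially where it was.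

Compound 4 `CCCN1CC[C@@]2(OC)OC(N)=C(C#N)[C@@H](c3ccc(Br)cc3)[C@@H]2C1` differs from compound 3 by ethyl in place of hydrogen on a saturated chain carbon bound to an amine nitrogen in a ring. Among the compounds with values here, the only measured step that touches this same place is a 1.1-fold higher number from compound 1 to compound 2 (0.06 log units; within the scatter), and it was flat. A smaller addition at the same position is therefore expected to change little: the estimated step is a 1.0-fold higher number from compound 3 to compound 4 (0.01 log units; within the scatter), not beyond the scatter. The expected value for compound 4 in this assay is 8000 nM, with a likely range from 3000 nM to 22000 nM.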

Compound 4, half-maximal inhibitory concentration: 19400 nM
For compound 4 the middle estimate is 2.4-fold (0.38 log units) below the measured one, within the range that was stated.
By their numbers in this assay, from the lowest: compound 3; then compounds 4, 1 and 2 (each within the scatter of the next).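

In this assay, the change from methyl to propyl on the bromo-bearing compound came with a 2.5-fold higher number from compound 3 to compound 4 (0.39 log units; beyond the scatter) and so weakened inhibition, which shows that this position is not indifferent to what is placed there. Within the data shown here, the only earlier step at this place, a 1.1-fold higher number from compound 1 to compound 2 (0.06 log units; within the scatter) and within the scatter, added phenyl to a compound without bromo, and that flat reading did not carry over to a smaller addition in the presence of bromo. Thus the larger group left the number unmoved on one compound, while the smaller ethyl moved it on the other, and nothing measured here gives a reason for this difference.

The two steps differ both in the group added and in the presence of bromo, so the compounds shown cannot tell which of the two sets the outcome, and phenyl added to compound 3 would separate them. They also leave open whether a longer chain such as butyl would continue the weakening seen with propyl, and how a chain ending in a hydroxyl group or a carboxylic acid would behave at this position.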